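The source may hold more compounds than are shown below. What is called first, only, known or untested is meant among the compounds shown, and "the series" means these compounds.

Compound 1 `CC1=CC[C@@H]([C@@](C)(O)CCCC(C)(C)NC=S)CC1`: 11400 nM
Compound 2 `COc1ccc(/C=N\NC(=S)NC(C)(C)CCC[C@](C)(O)[C@@H]2CC=C(C)CC2)cc1`: 7420 nM

In a functional assay on HT-29 cells (Homo sapiens) for cytotoxicity, read by sulforhodamine B assay (on this read-out lower numbers stand for stronger inhibition of growth and higher numbers for weaker inhibition of growth), compound 2 gives 7420 nM, which lies within the scatter of the value for compound 1, 11400 nM. The two cannot be told apart. Compound 3 `CC1=CC[C@@H]([C@@](C)(O)CCCC(C)(C)NC(=S)N/N=C\c2cccc([N+](=O)[O-])c2)CC1` has not yet been measured, and it differs from compound 2 as follows: 3-nitrophenyl in place of 4-methoxyphenyl on a carbon with a double bond to nitrogen. That is, 3-nitrophenyl stands in place of 4-methoxyphenyl on a carbon with a double bond to nitrogen. Among the compounds with values here, no measured pair isolates a single change, so no step beyond the scatter is expected in this assay, in either direction. The expected step is a 1.2-fold lower number from compound 2 to compound 3 (0.09 log units; within the scatter). For compound 3 the estimated value is 6000 nM, with an expected range of 2500 nM to 14000 nM.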

Compound 3, concentration for 50% growth inhibition: 14100 nM
The estimate for compound 3 lay 2.4-fold (0.37 log units) below the measured number; the whole stated range lies below it.
By their numbers in this assay, from the lowest: compounds 2, 1 and 3 (each within the scatter of the next).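

With 3-nitrophenyl in place of 4-methoxyphenyl on a carbon with a double bond to nitrogen, the pair gives a 1.9-fold higher number from compound 2 to compound 3 (0.28 log units; within the scatter) in this assay. This is the only comparison shown that isolates a single place, and it shows that these two aryl groups cannot be told apart at this position. Nothing measured here bears on why.

Going by these compounds, whether an unsubstituted phenyl, a pyridine or a carboxylic acid at this place would give a step beyond the scatter remains open. So does the effect of any alteration to the shared core.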